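A few compounds are considered here, and "the series" means these few. Any claim that something is new, unique, unknown or untested is made for them only; others in the source may bear on it.

Of the compounds shown here, three sharing one core have been measured in an assay (strain Wistar) for displacement of a labelled ligand from adenosine receptor A1 (Rattus norvegicus), read by scintillation counting; on this read-out higher numbers stand for weaker inhibition and lower numbers for stronger inhibition. Compound 1 `COc1ccccc1C(=O)Nc1nc(-c2ccccc2)nc2c1nnn2Cc1ccccc1` gives 1520 nM. Compound 2 `O=C(Nc1nc(-c2ccccc2)nc2c1nnn2Cc1ccccc1)C1CC1` gives 7.5 nM. Compound 3 `COc1ccc(Cl)cc1C(=O)Nc1nc(-c2ccccc2)nc2c1nnn2Cc1ccccc1` gives 7150 nM, the highest of the three numbers; a 4.7-fold higher number from compound 1 to compound 3 (0.67 log units; beyond the scatter) and a 950-fold higher number from compound 2 to compound 3 (2.98 log units; beyond the scatter) are both beyond the scatter, so compound 3 is the weakest of the set. Compound 4 `O=C(Nc1nc(-c2ccccc2)nc2c1nnn2Cc1ccccc1)C1CCCC1` has not yet been measured; it differs from compound 3 by cyclopentyl in place of 5-chloro-2-methoxyphenyl on a carbonyl carbon. The closest guide is a 950-fold higher number from compound 2 to compound 3 (2.98 log units; beyond the scatter), which put 5-chloro-2-methoxyphenyl in place of cyclopropyl and was large. Undoing that kind of exchange with cyclopentyl, a large lower number is expected in this assay, estimated as a 480-fold lower number from compound 3 to compound 4 (2.68 log units; beyond the scatter). Compound 4 is therefore expected to give about 15 nM, within 4 nM to 60 nM.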

Compound 4, inhibition constant: 2.5 nM
The estimate for compound 4 lay 6.0-fold (0.78 log units) above the measured number; measured number outside the range, below it.
By their numbers in this assay, from the lowest: compound 4; then compound 2; then compound 1; then compound 3.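

Replacing an aromatic group with cyclopentyl on this carbonyl carbon gives a 2900-fold lower number from compound 3 to compound 4 (3.46 log units; beyond the scatter) when 5-chloro-2-methoxyphenyl leaves and a 610-fold lower number from compound 1 to compound 4 (2.78 log units; beyond the scatter) when 2-methoxyphenyl leaves. The low number seen with cyclopropyl is therefore not unique to that group, since a second non-aromatic ring also gives one. Ring size matters too, though much less: going from cyclopropyl to cyclopentyl gives a 3.0-fold lower number from compound 2 to compound 4 (0.48 log units; beyond the scatter) and makes compound 4 the strongest of the four.

As far as these compounds go, whether cyclohexyl, an open propyl chain or an amine at this place would keep the number low remains open. Nothing available here explains these differences.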